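Chloro in Place of Fluoro on Compound 2

The source may hold more compounds than are shown below. What is called first, only, known or untested is meant among the compounds shown, and "the series" means these compounds.

Compound 1 `Nc1cccc(-c2cn3nc(-c4cccs4)sc3n2)c1`: > 250000 nM
Compound 2 `C=C(Br)C(=O)Nc1cccc(-c2cn3nc(-c4ccc(F)cc4)sc3n2)c1`: 830 nM

In a functional assay on CCRF-CEM cells (Homo sapiens) for inhibition, read by cell counting, with a stated time of 3 days (on this read-out lower numbers stand for stronger inhibition and higher numbers for weaker inhibition), compound 1 gives > 250000 nM, which is a limit of the assay rather than a number. In this assay compound 2 gives 830 nM, the only number shown. The result of compound 1 is a limit (the limit of > 250000 nM in this assay, at which 1 of the 2 values shown sits). Compound 3 `C=C(Br)C(=O)Nc1cccc(-c2cn3nc(-c4ccc(Cl)cc4)sc3n2)c1` differs from compound 2 by chloro in place of fluoro on an aromatic carbon. Within the data shown here, no measured step between two compounds exists here, so no step beyond the usual scatter is expected in either direction. Compound 3 is therefore expected near 700 nM, ranging from 250 nM to 2000 nM. The expected step is a 1.2-fold lower number from compound 2 to compound 3 (0.07 log units; within the scatter).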

Compound 3, half-maximal inhibitory concentration: 3200 nM
Compound 3: the middle estimate sits 4.6-fold (0.66 log units) below what was measured; measured number above the stated range.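

In this assay, among these compounds, going from 4-fluorophenyl to 4-chlorophenyl gives a 3.9-fold higher number from compound 2 to compound 3 (0.59 log units; beyond the scatter), the first step that can be read at this position. It shows that the aromatic carbon para to a large group is not indifferent to this exchange of one heavy atom, although the change adds no ring, charge, donor or acceptor. Nothing shown accounts for the size or direction of this step.

This single pair gives no trend across substituents. On these data alone, how hydrogen, bromo, methoxy or an amine on the same carbon would compare remains open.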